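Ethoxy to butoxy on a shared core

The compounds below may be only part of what the source reports. "The series", "measured", "known", "first", "only" and "open" are said of these compounds alone.

- compound 1 `COC[C@H]1O[C@@H](n2c(Cl)nc3cc(Cl)c(Cl)cc32)[C@H](OC(C)=O)[C@@H]1OC(C)=O` gives 26000 nM in a functional assay on HFF cells (Homo sapiens) for cytotoxicity; a higher number here means a weaker inhibitor, a lower number a stronger inhibitor
- compound 2 `CCOC[C@H]1O[C@@H](n2c(Cl)nc3cc(Cl)c(Cl)cc32)[C@H](OC(C)=O)[C@@H]1OC(C)=O` gives 33000 nM in this assay
- compound 3 `CCCCOC[C@H]1O[C@@H](n2c(Cl)nc3cc(Cl)c(Cl)cc32)[C@H](OC(C)=O)[C@@H]1OC(C)=O` has no value yet

Compound 2 lies within the scatter of compound 1, so the two cannot be ranked. The change to compound 3 is ethyl in place of hydrogen on a saturated chain carbon, two bonds along the chain from an oxygen on a saturated carbon and reads ethoxy to butoxy. For the measured compounds named here, one measured step bears on it: a 1.3-fold higher number from compound 1 to compound 2 (0.10 log units; within the scatter) is the same chain grown by methyl in place of hydrogen, and it stayed within the scatter. No step beyond the scatter is therefore expected in this assay and no direction is favoured. The estimated step is a 1.1-fold higher number from compound 2 to compound 3 (0.03 log units; within the scatter) in size. For compound 3 the estimate is 35000 nM with 16000 nM to 75000 nM as the expected range.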

Compound 3, half-maximal inhibitory concentration: 66000 nM
Compound 3: middle estimate off by 1.9-fold (0.28 log units), on the low side, and the stated range covers the measured number.
By their numbers in this assay, from the lowest: compounds 1, 2 and 3 (each within the scatter of the next, the first and the last beyond it).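

Taken alone, a 2.0-fold higher number from compound 2 to compound 3 (0.30 log units; within the scatter) in this assay remains within the scatter, but the two ends of the series now separate, with a 2.5-fold higher number from compound 1 to compound 3 (0.40 log units; beyond the scatter) in the same assay. For the compounds shown here, compound 1 and compound 2 could not be ranked, so this is the first sign that growing this chain to butoxy can shift the number, here towards a weaker inhibitor, though only modestly. No measurement offered here accounts for this shift. The compounds shown leave open whether a longer chain such as hexyloxy would extend the trend, and how an amine in place of the butoxy would behave.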